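A few compounds are considered here, and "the series" means these few. Any claim that something is new, unique, unknown or untested is made for them only; others in the source may bear on it.

Compound 1 `O=C(/C=C/C=C/c1ccccc1)c1ccccc1` and compound 2 `O=C(/C=C/C=C/c1ccccc1)c1cccc(O)c1` differ in one place: hydroxy in place of hydrogen on an aromatic carbon. In an ADME assay on RAW264.7 cells (Mus musculus) for cytotoxicity, read by MTT assay (a lower number here means a stronger inhibitor, a higher number a weaker inhibitor), compound 1 gives 44300 nM, and in this assay compound 2 gives 48700 nM; the step is a 1.1-fold higher number from compound 1 to compound 2 (0.04 log units; within the scatter).

Compound 3 `COc1ccc(/C=C/C=C/C(=O)c2ccc(OC)cc2)cc1` and compound 4 `COc1ccc(/C=C/C=C/C(=O)c2ccc(OC)c(O)c2)cc1` carry the same kind of change, (hydroxy in place of hydrogen on an aromatic carbon), on a different core. How the core of compound 3 differs from the core of compound 1 is not broken down here. The place also is not identical word for word: in compound 4 the entering hydroxy sits ortho to a methoxy group (2 heavy atoms) as well as meta to a large group, whereas in compound 2 it sits only meta to a large group. In this assay compound 3 gives "not determined" (no result reported), so no single number for compound 3 is available.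

Compound 4 is therefore estimated from compound 1 and compound 2 alone. Because a 1.1-fold higher number from compound 1 to compound 2 (0.04 log units; within the scatter) lies within the scatter, a step of similar small size is expected for compound 4 in this assay, with no numerical anchor for its core. Compound 4 is expected to give about 45000 nM in this assay, with a range from 18000 nM to 110000 nM.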

Compound 4, half-maximal inhibitory concentration: 28400 nM
Estimate against measurement, compound 4: 1.6-fold (0.20 log units) above, and the stated range covers the measured number.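

In this assay compound 4 gives 28400 nM and compound 3 has no single number, so no new step can be read between compound 3 and compound 4. The compounds shown leave open what hydroxy in place of hydrogen, ortho to a methoxy group, does on this core. Nothing shown here offers an explanation for the result.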